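Three limits before a phenyl-for-propyl exchange

A few compounds are considered here, and "the series" means these few. Any claim that something is new, unique, unknown or untested is made for them only; others in the source may bear on it.

Compound 1 `CSc1nncc2c(C(C)C)ncn12` in a functional assay for inhibition, with Homo sapiens as the target (a higher number here means a weaker inhibitor, a lower number a stronger inhibitor), gives > 48000 nM, which is a limit of the assay.
Compound 2 `C=CCSc1nncc2cnc(CCC)n12` in this assay gives > 48000 nM, which is a limit of the assay.
Compound 3 `C=CCn1ncc2c(Br)nc(Cc3ccccc3)n2c1=O` in this assay gives > 48000 nM, which is a limit of the assay.

Compound 2 therefore stands exactly where the other two stand: at the limit of > 48000 nM in this assay, at which 3 of the 3 values shown sit. Because its value is a limit, no order among the three can be drawn. Compound 4 `C=CCSc1nncc2cnc(-c3ccccc3)n12` differs from compound 2 in one place, (phenyl in place of propyl on an aromatic carbon). Within the data shown here, no measured pair shows what this exchange does, so the step that the limit leaves unreadable from compound 2 to compound 4 is expected to be none beyond the scatter, with the likeliest outcome that compound 4 again reaches only the limit. Compound 4 is estimated at 60000 nM, within 15000 nM to 250000 nM.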

Compound 4, half-maximal inhibitory concentration: > 48000 nM
Compound 4: only a limit was reported; the forecaster's own chance of this, stated with the estimate: 80%; the middle value is on the limit's open side.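

Compound 2 and compound 4 both reach only a limit of the assay, so no step can be read for phenyl in place of propyl: the limit of > 48000 nM in this assay, at which 4 of the 4 values shown sit.

The compounds shown leave open how strongly any of them inhibits, and whether this exchange alters that at all.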